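Adding a Butyl Chain to Compound 3

A few compounds are considered here, and "the series" means these few. Any claim that something is new, unique, unknown or untested is made for them only; others in the source may bear on it.

Three compounds share a two-ring core carrying a benzyloxy group, and all were tested in a functional assay on the whole organism with Rattus norvegicus as the target, at a dose of 40 mg/kg by the intraperitoneal route; on this read-out lower numbers stand for less inhibition and higher numbers for more inhibition at the one dose given (going by the name of the read-out). Compound 1, `Cc1cc(OCc2ccccc2)c2nc(C)c(C)n2c1`, gives 86% in this assay. Compound 2, `Cc1ccn2c(C)c(C)nc2c1OCc1ccccc1`, gives 92%. Compound 3, `Nc1cnc2c(OCc3ccccc3)cccn12`, gives only 32%, the lowest of the three numbers: its gap to compound 1 and its gap to compound 2 both lie well beyond the usual scatter, so compound 3 clearly has the lowest number of the set.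

Compound 4, `CCCCc1nc2c(OCc3ccccc3)cccn2c1N`, has not yet been measured. It differs from compound 3 in one place: butyl in place of hydrogen on an aromatic carbon. Among the compounds with values here, no pair of measured compounds differs in exactly this way, so there is no measured step to lean on. Because compound 3 sits low at 32% while the two related compounds 1 and 2 sit high, a moderate rise is expected, though a change of this size remains uncertain. The estimated step from compound 3 to compound 4 is a number 18 percentage points higher from compound 3 to compound 4 (beyond the scatter). Compound 4 is therefore expected to give about 50% in this assay, within a range of 25% to 75%.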

Compound 4, a percentage reported as inhibition, in the whole organism at one dose (the size of the read-out at that dose, not a potency): 26%
Estimate against measurement, compound 4: 24 percentage points above; low and high end bracket the measured number.
By their numbers in this assay, from the lowest: compounds 4 and 3 (each within the scatter of the next); then compounds 1 and 2 (each within the scatter of the next).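

Within the data shown here, putting butyl in place of hydrogen on an aromatic carbon of the five-membered ring, next to the ring atom that bears an amino group, gives the first measured step at this position: in this assay, the change is a number 6 percentage points lower from compound 3 to compound 4 (within the scatter). Compound 3 and compound 4 therefore cannot be told apart in this read-out, so this carbon can carry a butyl chain without a clear shift in the number at this dose. Nothing measured here offers an explanation for this result.

The compounds shown leave open whether a longer chain, such as octyl, or a carboxylic acid on this same carbon would move the number beyond the scatter. They also leave open how butyl would behave here if the amino group were replaced by another group.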